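A carboxyphenyl swap on compound 2

The source may hold more compounds than are shown below. What is called first, only, known or untested is meant among the compounds shown, and "the series" means these compounds.

Measured compounds:
- compound 1 `CN1CCN(C2CCN(c3nccc4[nH]c(-c5ccc(F)c(C(F)(F)F)c5)nc34)CC2)CC1` gives 195000 nM
- compound 2 `CN1CCN(CC2CCN(c3nccc4[nH]c(-c5ccc(F)c(C(F)(F)F)c5)nc34)CC2)CC1` gives 165000 nM

Among the measured compounds shown here, in a physicochemical assay for solubility, read by HPLC, using the shake flask method, in phosphate buffer, with a stated time of 20 h, at pH 6.5 (a lower number here means a less soluble compound, a higher number a more soluble compound), compound 2 stands at 165000 nM and compound 1 at 195000 nM on the only two numbers available, and these two lie within the scatter of each other. For the measured compounds named here, the one measured step is a 1.2-fold lower number from compound 1 to compound 2 (0.07 log units; within the scatter) for (4-methylpiperazin-1-yl)methyl in place of 4-methylpiperazin-1-yl on a saturated ring carbon.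

Compound 3 `CN1CCN(CC2CCN(c3nccc4[nH]c(-c5cccc(C(=O)O)c5)nc34)CC2)CC1` differs from compound 2 at another place, with 3-carboxyphenyl in place of 4-fluoro-3-(trifluoromethyl)phenyl on an aromatic carbon of a five-membered aromatic ring with 2 nitrogen. Going by the values given here, the measured step touches a different part of the molecule, so it bears on this change only weakly, and no measured pair varies this aromatic group. The data therefore give no size for the change. The expectation rests on the structural change alone and points to a higher number in this assay with wide uncertainty. The expected change is a 2.4-fold higher number from compound 2 to compound 3 (0.38 log units; beyond the scatter) in this estimate. For compound 3 the estimated value is 400000 nM with an expected range from 100000 nM to 1200000 nM in this assay.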

Compound 3, solubility: 195000 nM
Beside the measured number, compound 3's estimate is 2.1-fold (0.31 log units) above it; measured number inside the range.
By their numbers in this assay, from the lowest: compounds 2, 1 and 3 (each within the scatter of the next).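

Among the compounds shown here, until now the only step in this assay lay on a saturated ring carbon, so this is the first look at the aromatic carbon of the five-membered aromatic ring with 2 nitrogen. At that place, a group carrying fluorine gives way to one carrying oxygen, a hydrogen-bond donor and a hydrogen-bond acceptor, and the result is a 1.2-fold higher number from compound 2 to compound 3 (0.07 log units; within the scatter), so this large change of substituent leaves no difference that can be read beyond the scatter, as was also true of the earlier step on the saturated ring carbon. No supporting information is available that would account for this result.

The compounds shown leave open whether other groups at this aromatic carbon, such as a primary amide, an amine or an unsubstituted phenyl, would also stay within the scatter of compound 2. They also leave open whether the same 3-carboxyphenyl swap would give a similar step on compound 1, where 4-methylpiperazin-1-yl sits directly on the saturated ring carbon, and which part of 4-fluoro-3-(trifluoromethyl)phenyl, the fluoro or the trifluoromethyl, matters at all in this measurement.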